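Methyl on the ring amine, carried to a second core

A few compounds are considered here, and "the series" means these few. Any claim that something is new, unique, unknown or untested is made for them only; others in the source may bear on it.

Compound 1 `O=S(=O)(c1cccc2ccccc12)c1cn(C2CCCNC2)c2ccccc12` and compound 2 `CN1CCCC(n2cc(S(=O)(=O)c3cccc4ccccc34)c3ccccc32)C1` share one core and differ only in methyl in place of hydrogen on an amine nitrogen in a ring. In an assay on HeLa cells for displacement of a labelled ligand from 5-hydroxytryptamine receptor 6 (Homo sapiens), with a stated time of 2 h (a higher number here means a weaker inhibitor, a lower number a stronger inhibitor), compound 1 gives 21 nM, and compound 2 gives 7.1 nM; the step is a 3.0-fold lower number from compound 1 to compound 2 (0.47 log units; beyond the scatter).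

Compound 3 `O=S(=O)(c1cccc(F)c1)c1cn(C2CCNC2)c2ccc(F)cc12` belongs to a second core; the difference between the two cores is not broken down here. In this assay compound 3 gives 9.6 nM, a number close to that of compound 2 and higher than that of compound 1.

Compound 4 `CN1CCC(n2cc(S(=O)(=O)c3cccc(F)c3)c3cc(F)ccc32)C1` repeats the change on compound 3 (methyl in place of hydrogen on an amine nitrogen in a ring). The surroundings are not identical: in compound 2 the amine nitrogen sits in a six-membered non-aromatic ring with 1 nitrogen, in compound 4 in a five-membered non-aromatic ring with 1 nitrogen, so this is the same kind of change rather than the same one.

Among the compounds with values here, the expected step of a 2.4-fold lower number from compound 3 to compound 4 (0.38 log units; beyond the scatter) is set beside a 3.0-fold lower number from compound 1 to compound 2 (0.47 log units; beyond the scatter), the only measured instance, and rests on that alone. Compound 4 is expected to give about 4 nM, within 1.5 nM to 10 nM.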

Compound 4, inhibition constant: 5 nM
Compound 4: the middle estimate sits 1.3-fold (0.10 log units) below what was measured; low and high end bracket the measured number.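

In this assay, methyl in place of hydrogen on the amine nitrogen of the five-membered ring gives a 1.9-fold lower number from compound 3 to compound 4 (0.28 log units; within the scatter), so on this core the step taken alone cannot be told apart from repeat scatter. The two instances of the change nevertheless agree as far as this assay can tell: the same change on two cores in this assay, a 3.0-fold lower number (0.47 log units; beyond the scatter) from compound 1 to compound 2 and a 1.9-fold lower number (0.28 log units; within the scatter) from compound 3 to compound 4, 1.5-fold (0.19 log units) apart, within the scatter of two such steps. This shows that the two pairs fit a single step of similar size, but two pairs make no rule for the series, and with both the ring size and the rest of the core differing between them, neither difference can be judged on its own.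

Left open is what a group other than methyl on that ring amine nitrogen, such as ethyl, a longer chain or acetyl, would do in this assay. Also open, as far as these compounds go, is whether the step stays the same when only the ring size changes and the rest of the core is held fixed.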